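The source may report more compounds than this note shows. Statements on the series, on what has been measured and on what is new or still open speak of the compounds shown alone.

Compound 1 `Cc1ccc(S(=O)(=O)/N=C(/CCNC2=CC(=O)c3ccccc3C2=O)Nc2ccc(F)cc2)cc1` is the reference point of this set. In a functional assay on DU-145 cells (Homo sapiens) for cytotoxicity, read by MTT assay, with a stated time of 48 h (on this read-out higher numbers stand for weaker inhibition and lower numbers for stronger inhibition), compound 1 gives 12200 nM, the lowest of the three numbers measured. Its two measured companions carry other groups on the same amine nitrogen: compound 2 `Cc1ccc(S(=O)(=O)/N=C(/CCNC2=CC(=O)c3ccccc3C2=O)Nc2cccc(C(F)(F)F)c2)cc1` gives 84100 nM in this assay, and compound 3 `COc1ccc(N/C(CCNC2=CC(=O)c3ccccc3C2=O)=N\S(=O)(=O)c2ccc(C)cc2)c(OC)c1` gives 67300 nM. The steps away from compound 1 both ran upward, a 6.9-fold higher number from compound 1 to compound 2 (0.84 log units; beyond the scatter) and a 5.5-fold higher number from compound 1 to compound 3 (0.74 log units; beyond the scatter), while compounds 2 and 3 sit within the scatter of each other, a 1.2-fold lower number from compound 2 to compound 3 (0.10 log units; within the scatter).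

The unmeasured compound 4 `Cc1ccc(S(=O)(=O)/N=C(/CCNC2=CC(=O)c3ccccc3C2=O)NC(C)C)cc1` changes that same position again: isopropyl in place of 4-fluorophenyl on an amine nitrogen. The two measured steps bear on it only loosely, since each swapped one six-membered aromatic ring of carbon only for another, whereas here the ring is lost altogether and isopropyl enters. Both measured changes at this nitrogen raised the number beyond the scatter, so a higher number is also expected for compound 4, though with wide uncertainty, an expected step of a 2.9-fold higher number from compound 1 to compound 4 (0.46 log units; beyond the scatter). The estimate for compound 4 in this assay is 35000 nM, expected to lie between 9000 nM and 130000 nM.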

Compound 4, half-maximal inhibitory concentration: 28500 nM
Compound 4: the middle estimate sits 1.2-fold (0.09 log units) above what was measured; measured number inside the range.
By their numbers in this assay, from the lowest: compound 1; then compound 4; then compounds 3 and 2 (each within the scatter of the next).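

Removing the ring from this amine nitrogen does not remove the effect of the substituent: isopropyl still reads above 4-fluorophenyl (a 2.3-fold higher number from compound 1 to compound 4 (0.37 log units; beyond the scatter)). Yet it reads below the other two aromatic groups (a 2.4-fold lower number from compound 3 to compound 4 (0.37 log units; beyond the scatter); a 3.0-fold lower number from compound 2 to compound 4 (0.47 log units; beyond the scatter)), so in this assay an aromatic ring at this position does not by itself give a lower number, and among the four compounds only compound 1, with its 4-fluorophenyl, reads below compound 4. Nothing available accounts for this order. The compounds shown leave open whether plain phenyl would keep the low number of compound 1, which would test the part played by the fluorine. They also leave open how cyclohexyl, benzyl or a longer chain such as n-butyl would read on this nitrogen.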